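A few compounds are considered here, and "the series" means these few. Any claim that something is new, unique, unknown or untested is made for them only; others in the source may bear on it.

For the measured compounds named here, compound 2 `CC(C(=O)NCc1ccc(C(F)(F)F)cc1SC1CCCCC1)c1ccc(NS(C)(=O)=O)c(F)c1` is one of two compounds measured in an assay on CHO cells for antagonist activity at transient receptor potential cation channel subfamily V member 1 (Homo sapiens), read by FLIPR (on this read-out lower numbers stand for stronger inhibition and higher numbers for weaker inhibition), where compound 2 gives 0.5 nM. Its closest neighbour is compound 1 `CC(C(=O)NCc1ccc(C(F)(F)F)cc1OC1CCCCC1)c1ccc(NS(C)(=O)=O)c(F)c1`, which in this assay gives 0.7 nM; the change a 1.4-fold lower number from compound 1 to compound 2 (0.15 log units; within the scatter) sits within the scatter, so the two compounds stand side by side rather than apart.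

Compound 3 `C[C@@H](C(=O)NCc1ccc(C(F)(F)F)cc1SC1CCCCC1)c1ccc(NS(C)(=O)=O)c(F)c1` is the next compound to be measured. It differs from compound 2 only in this way: the two compounds have the same atoms and bonds; at least one stereo element is drawn with a configuration in one of them and without one in the other: 1 of 1 stereo elements differ; a stereocentre at a saturated chain carbon is drawn without a configuration in compound 2 and R in compound 3. In plain terms, compound 2 is drawn as a mixture at that stereocentre, and compound 3 is drawn as the single form with the R configuration, while all atoms and bonds stay the same.

Going by the values given here, none of the measured steps bears on this kind of change; the one step in hand, from compound 1 to compound 2, swaps an oxygen-linked ring for a sulfur-linked ring and says nothing about stereochemistry. The number for compound 3 could therefore fall close to that of compound 2, or away from it if the single form carries little of the activity of the mixture.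

Compound 3 is estimated at 0.5 nM in this assay, with a range from 0.15 nM to 5 nM, which means an expected step of no change at the digits printed from compound 2 to compound 3 (within the scatter).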

Compound 3, inhibition constant: 13.9 nM
Compound 3: the middle estimate sits 28-fold (1.44 log units) below what was measured; the measured number lies above the stated range.
By their numbers in this assay, from the lowest: compounds 2 and 1 (each within the scatter of the next); then compound 3.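

In this assay, the stereocentre at the saturated chain carbon turns out to matter, something compound 1 and compound 2 could not show, since they differ only in the atom linking the cyclohexyl ring: drawing this centre as R brings a 28-fold higher number from compound 2 to compound 3 (1.44 log units; beyond the scatter). Atoms and bonds stay the same, so this large step can be tied only to this one centre and the way it is drawn: the fact that one of compounds 2 and 3 is drawn with a defined configuration and the other without, at the place where they differ A compound drawn without a configuration can hold more than one form at that carbon, and the R form alone does not reproduce the low number of compound 2, which suggests that the S form may carry much of the activity.

The compounds shown leave open how the single S form would read in this assay, and whether a similar gap between the forms would appear with the cyclohexyloxy group of compound 1 in place of cyclohexylsulfanyl. They also leave open whether an amine nitrogen as the link to the cyclohexyl ring, or a cyclopentyl ring in its place, would keep the number as low.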